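The compounds below may be only part of what the source reports. "The series", "measured", "known", "first", "only" and "open" are said of these compounds alone.

Measured in a functional assay on M21 cells (Homo sapiens) for antiproliferative activity, read by sulforhodamine B assay, with a stated time of 48 h; a higher number here means a weaker inhibitor, a lower number a stronger inhibitor:
- compound 1 `O=C1NCCN1c1ccc(S(=O)(=O)Nc2ccc(I)cc2)cc1`: 260 nM
- compound 2 `CCc1ccc(NS(=O)(=O)c2ccc(N3CCNC3=O)cc2)cc1`: 480 nM

Not yet measured:
- compound 3 `CCCCCCCc1ccc(NS(=O)(=O)c2ccc(N3CCNC3=O)cc2)cc1`

Among the measured compounds shown here, compound 2 gives 480 nM, a number that cannot be told apart from the one for compound 1, 260 nM. With only these two measurements, neither can be ranked above the other.

Compound 3 lengthens the ethyl group of compound 2 into a heptyl chain: pentyl in place of hydrogen on a saturated chain carbon, two bonds along the chain from an aromatic carbon.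

For the measured compounds named here, only one measured step bears on this change: a 1.8-fold higher number from compound 1 to compound 2 (0.27 log units; within the scatter), with ethyl in place of iodo on an aromatic carbon. That step lies within the scatter, and it concerns the same part of the molecule. However, no chain longer than ethyl has been measured, so it offers only weak guidance on direction. A slightly higher number is expected, but no clear step beyond the scatter. The expected change is a 1.7-fold higher number from compound 2 to compound 3 (0.22 log units; within the scatter). Compound 3 is estimated at 800 nM, with an expected range of 150 nM to 3500 nM.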

Compound 3, half-maximal inhibitory concentration: > 1000 nM
Compound 3 was reported as a limit; the forecaster's own chance of this, stated with the estimate: 10%; middle value at least 1.2-fold (0.09 log units) from the limit.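

In this assay compound 3 gives > 1000 nM, which is a limit and not an exact number. Even so, the limit is enough to show a change that the earlier pair could not: lengthening ethyl to heptyl gives an at least 2.0-fold higher number from compound 2 to compound 3 (0.31 log units; beyond the scatter), and putting heptyl in place of iodo gives an at least 3.8-fold higher number from compound 1 to compound 3 (0.58 log units; beyond the scatter). Iodo and ethyl at this position could not be told apart, but the heptyl chain moves the result beyond the scatter towards a weaker inhibitor, although the full size of that loss stays unknown: the limit of > 1000 nM in this assay, at which 1 of the 3 values shown sits.

Open questions remain about the length at which the loss begins, and whether a butyl chain would stay close to ethyl or fall with heptyl. On these data alone, it is also open whether a chain of similar length ending in an amine or a carboxylic acid would weaken the inhibitor in the same way as the plain heptyl chain.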